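Changing the sulfonyl aryl group of compound 1

A few compounds are considered here, and "the series" means these few. Any claim that something is new, unique, unknown or untested is made for them only; others in the source may bear on it.

In a functional assay on K562 cells (Homo sapiens) for inhibition, read by trypan blue exclusion, with a stated time of 72 h (on this read-out higher numbers stand for weaker inhibition and lower numbers for stronger inhibition), compound 1 `Cn1c(=O)c(S(=O)(=O)c2ccc(Cl)cc2)cc2cnc(Nc3ccc4[nH]ccc4c3)nc21` gives 100 nM, the lowest of the two numbers seen. Compound 2 `Cn1c(=O)c(S(=O)(=O)c2ccc(Cl)cc2)cc2cnc(Nc3cnc4ccccc4c3)nc21` gives 15000 nM, and the step of a 150-fold higher number from compound 1 to compound 2 (2.18 log units; beyond the scatter) came from quinolin-3-yl in place of 1H-indol-5-yl on a nitrogen on an aromatic ring. Compound 3 `Cn1c(=O)c(S(=O)(=O)c2ccc(F)cc2N)cc2cnc(Nc3ccc4[nH]ccc4c3)nc21` differs from compound 1 elsewhere: 2-amino-4-fluorophenyl in place of 4-chlorophenyl on a sulfonyl sulfur. For the measured compounds named here, no measured step touches the group on the sulfonyl sulfur, so that large step gives no guide here. With nothing to rest on, the estimate for compound 3 is a step of a 1.5-fold higher number from compound 1 to compound 3 (0.18 log units; within the scatter) that stays within the scatter, an expected value of 150 nM ranging from 40 nM to 600 nM.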

Compound 3, half-maximal inhibitory concentration: 2000 nM
Estimate against measurement, compound 3: 13-fold (1.12 log units) below; the whole stated range lies below it.
By their numbers in this assay, from the lowest: compound 1; then compound 3; then compound 2.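

In this assay the group on the sulfonyl sulfur also counts, not only the group on the aromatic amine nitrogen: 2-amino-4-fluorophenyl in place of 4-chlorophenyl brings a 20-fold higher number from compound 1 to compound 3 (1.30 log units; beyond the scatter) and so weaker inhibition. This single step changes two things on the ring, as chlorine gives way to fluorine and an amino group enters, and it cannot separate them. No measured property is at hand to explain the result. For the compounds shown here, still open is how 4-fluorophenyl or 2-amino-4-chlorophenyl on the sulfonyl sulfur would read, each carrying only one of the two changes.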